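The compounds below may be only part of what the source reports. "The series", "measured", "known", "first", "only" and "open" are said of these compounds alone.

Compound 1 `COc1ccc(/C=C/c2cc(OC)cc(OC)c2/C=C/C(=O)c2cc3ccccc3oc2=O)cc1` gives 41700 nM in an assay on isolated protein for inhibition of Amine oxidase [flavin-containing] A (Homo sapiens), read by fluorescence, with a stated time of 15 min; a higher number here means a weaker inhibitor, a lower number a stronger inhibitor. Compound 2 `COc1ccc(/C=C/c2cc(OC)cc(OC)c2/C=C/C(=O)c2cc3ccc(Cl)cc3oc2=O)cc1` gives > 60000 nM in this assay, which is a limit of the assay and not a number. Compound 2 therefore sits at the limit of > 60000 nM in this assay, at which 1 of the 2 values shown sits. Among the compounds with values here, the only measured step is an at least 1.4-fold higher number from compound 1 to compound 2 (0.15 log units; that floor lies within the scatter), and it rests on that limit. Compound 3 `COc1ccc(/C=C/c2cc(OC)cc(OC)c2/C=C/C(=O)c2cc3cccc(C)c3oc2=O)cc1` differs from compound 2 by a group of 12 heavy atoms (10 carbon, 2 oxygen; one six-membered aromatic ring of carbon only, one six-membered aromatic ring with 1 hetero atom) in place of a group of 12 heavy atoms (9 carbon, 2 oxygen, 1 chlorine; one six-membered aromatic ring of carbon only, one six-membered aromatic ring with 1 hetero atom), on a carbonyl carbon. Within the data shown here, no measured step covers this exchange, so in this assay a change of no more than an at least 1.0-fold lower number from compound 2 to compound 3 (0.03 log units; that floor lies within the scatter) is expected, within the scatter. Compound 3 is estimated at 55000 nM, between 20000 nM and 150000 nM.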

Compound 3, half-maximal inhibitory concentration: > 60000 nM
Compound 3 gave a limit, no number (the forecaster's own chance of this, stated with the estimate: 45%); middle value at least 1.0-fold (0.03 log units) away from the limit.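

A methyl group gives an at least 1.4-fold higher number from compound 1 to compound 3 (0.15 log units; that floor lies within the scatter), so a second single change to compound 1 also ends without a readable number, and this step rests on a limit. In this assay, compound 3 gives > 60000 nM, which is a limit of the assay, and the step between compound 2 and compound 3 cannot be read. The chloro and methyl compounds now stand at the same limit: the limit of > 60000 nM in this assay, at which 2 of the 3 values shown sit.

What the compounds shown leave open is how far either change truly reaches beyond that limit. They also leave open whether an amine or a carboxylic acid on that aromatic carbon would give a number that can be read.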